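Removing the chloromethyl from compound 2's chain

The source may report more compounds than this note shows. Statements on the series, on what has been measured and on what is new or still open speak of the compounds shown alone.

Measured in a functional assay on M21 cells (Homo sapiens) for cytotoxicity, read by sulforhodamine B assay, with a stated time of 48 h; on this read-out lower numbers stand for stronger inhibition and higher numbers for weaker inhibition:
compound 1 `CCc1ccccc1OS(=O)(=O)c1ccc(NC(=O)NCCCCl)cc1` gives 15000 nM
compound 2 `CCCc1ccccc1OS(=O)(=O)c1ccc(NC(=O)NCCCCl)cc1` gives 13000 nM
compound 3 `O=C(NCCCCl)Nc1ccc(S(=O)(=O)Oc2ccc(O)cc2)cc1` gives 47000 nM

Compound 2 stands at the low end of these three numbers, with a 1.2-fold lower number from compound 1 to compound 2 (0.06 log units; within the scatter) as the gap to its nearest neighbour and a 3.6-fold higher number from compound 2 to compound 3 (0.56 log units; beyond the scatter) as the gap to the furthest. Compound 4 `CCCc1ccccc1OS(=O)(=O)c1ccc(NC(=O)NCC)cc1` changes compound 2 in one place, (hydrogen in place of chloromethyl on a saturated chain carbon, two bonds along the chain from an amide-type nitrogen), which is hydrogen in place of chloromethyl on a saturated chain carbon, two bonds along the chain from an amide-type nitrogen. The 3-chloropropyl group thus becomes ethyl. Among the compounds with values here, no measured step touches this group, so the data hold no direct comparison. The only rough scale is a change elsewhere in the molecule, a 3.6-fold higher number from compound 2 to compound 3 (0.56 log units; beyond the scatter), and a 3.1-fold higher number from compound 1 to compound 3 (0.50 log units; beyond the scatter) is of similar size. A modest move to a higher number is therefore expected in this assay, though this is weakly supported. The expected step is a 2.3-fold higher number from compound 2 to compound 4 (0.36 log units; beyond the scatter). For compound 4 the estimate is 30000 nM, with an expected range of 10000 nM to 100000 nM.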

Compound 4, half-maximal inhibitory concentration: 800 nM
The estimate for compound 4 lay 38-fold (1.57 log units) above the measured number; measured number below the stated range.
By their numbers in this assay, from the lowest: compound 4; then compounds 2 and 1 (each within the scatter of the next); then compound 3.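

Cutting the 3-chloropropyl group back to ethyl gives a 16-fold lower number from compound 2 to compound 4 (1.21 log units; beyond the scatter) in this assay and is the largest step in this set. Compounds 1, 2 and 3 all carry the 3-chloropropyl group and differ only elsewhere, so they could not show how much this chain position matters; their steps, such as a 3.6-fold higher number from compound 2 to compound 3 (0.56 log units; beyond the scatter) and a 1.2-fold lower number from compound 1 to compound 2 (0.06 log units; within the scatter) on the same read-out, are much smaller. The change removes a chloromethyl, one carbon and one chlorine together, and nothing available gives a reason for the size of this step.

The step therefore cannot be divided between the loss of chlorine and the shorter chain. As far as these compounds go, a plain propyl chain or a 2-chloroethyl chain on this nitrogen would separate the two, and it remains open whether the ethyl group would have the same effect alongside the other aryl groups of compound 1 or compound 3.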